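The source may report more compounds than this note shows. Statements on the series, on what has been measured and on what is new or still open speak of the compounds shown alone.

Measured compounds in a functional assay on NCI-H1975 cells (Homo sapiens) for inhibition, read by MTT assay, with a stated time of 72 h; on this read-out lower numbers stand for stronger inhibition and higher numbers for weaker inhibition:
Compound 1, `C=CC(=O)Nc1cccc(NC(=O)CSc2nc(Nc3cccc(F)c3)c3ccccc3n2)c1`, gives 2030 nM.
Compound 2, `C=CC(=O)Nc1cccc(NC(=O)CSc2nc(Nc3ccc(F)cc3)c3ccccc3n2)c1`, gives 4430 nM.

Compound 2 stands at the higher of the two numbers in this assay. For the measured compounds named here, the only measured step, a 2.2-fold higher number from compound 1 to compound 2 (0.34 log units; beyond the scatter), moves a fluorine from one position of the phenyl to another and does not change the halogen itself.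

Compound 3, `C=CC(=O)Nc1cccc(NC(=O)CSc2nc(Nc3ccc(Cl)cc3)c3ccccc3n2)c1`, differs from compound 2 by chloro in place of fluoro on an aromatic carbon. Going by the values given here, no measured step bears directly on swapping one halogen for another at this position, so the expectation rests on compound 2 alone, and the expected step is a 1.1-fold lower number from compound 2 to compound 3 (0.04 log units; within the scatter), no larger than the scatter. Compound 3 is therefore estimated at 4000 nM in this assay, between 1500 nM and 11000 nM.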

Compound 3, half-maximal inhibitory concentration: 7580 nM
Compound 3: middle estimate off by 1.9-fold (0.28 log units), on the low side, within the range that was stated.
By their numbers in this assay, from the lowest: compound 1; then compounds 2 and 3 (each within the scatter of the next).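

In this assay, chloro in place of fluoro on this aromatic carbon, para to a large group, gives a 1.7-fold higher number from compound 2 to compound 3 (0.23 log units; within the scatter), so these two halogens cannot be told apart here. The wider change, which alters both the halogen and its place, gives a 3.7-fold higher number from compound 1 to compound 3 (0.57 log units; beyond the scatter), and compound 1 stays apart from both para-substituted compounds. Nothing measured alongside these numbers accounts for them.

Still open, going by these compounds, is how an amine or a methoxy group on the same aromatic carbon would read, and whether chloro at the place of the fluorine in compound 1 would match compound 1.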